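Sulfur chain length and the step to compound 4

The source may hold more compounds than are shown below. What is called first, only, known or untested is meant among the compounds shown, and "the series" means these compounds.

Values in a functional assay on MOLT-3 cells (Homo sapiens); on this read-out higher numbers stand for weaker inhibition and lower numbers for stronger inhibition:
- compound 1 `CSC[C@H](NC(C)=O)C(=O)CCl`: 80800 nM
- compound 2 `CCCCCCSC[C@H](NC(C)=O)C(=O)CCl`: 700 nM
- compound 3 `CCCCCCCSC[C@H](NC(C)=O)C(=O)CCl`: 2500 nM

Compound 3 has the second highest of the three numbers in this assay, lying above compound 2 and below compound 1. Compound 4 `CCCCCCCCCCCCCCCSC[C@H](NC(C)=O)C(=O)CCl` differs from compound 3 by octyl in place of hydrogen on a saturated chain carbon, seven bonds along the chain from a sulfur.

Among the measured compounds shown here, three measured steps bear on this change. Two large ones start from the compound with the smallest group on sulfur: a 120-fold lower number from compound 1 to compound 2 (2.06 log units; beyond the scatter) and a 32-fold lower number from compound 1 to compound 3 (1.51 log units; beyond the scatter). For the measured compounds named here, the closest precedent is a 3.6-fold higher number from compound 2 to compound 3 (0.55 log units; beyond the scatter), which is modest and runs towards weaker inhibition. Going by the values given here, that single extension is the only guide, and no measured compound carries a chain approaching the length of the one in compound 4. A further modest rise in this assay, beyond the scatter but with wide uncertainty, is therefore expected. The expected change is a 4.0-fold higher number from compound 3 to compound 4 (0.60 log units; beyond the scatter). For compound 4 the estimated value is 10000 nM, with an expected range of 2500 nM to 50000 nM.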

Compound 4, half-maximal inhibitory concentration: 8600 nM
Compound 4: middle estimate off by 1.2-fold (0.07 log units), on the high side; low and high end bracket the measured number.
By their numbers in this assay, from the lowest: compound 2; then compound 3; then compound 4; then compound 1.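

In this assay, octyl in place of hydrogen at this position gives a 3.4-fold higher number from compound 3 to compound 4 (0.54 log units; beyond the scatter), a modest move for a far larger addition, close in printed size to the methyl step a 3.6-fold higher number from compound 2 to compound 3 (0.55 log units; beyond the scatter). The number thus rises in the same direction across both extensions, yet compound 4 at 8600 nM remains below compound 1 at 80800 nM, so the longest chain shown keeps much of the gain over the compound with the smallest group on sulfur. Nothing measured here accounts for this trend with chain length.

On these data alone, the chain lengths between those of compound 1 and compound 2 remain open, so it is unclear where the lowest number lies. Also open, as far as these compounds go, is how an amine or a carboxylic acid on the chain, or a still longer chain, would read.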